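The source may report more compounds than this note shows. Statements on the series, on what has been measured and on what is new or still open speak of the compounds shown alone.

Measured so far:
compound 1 `CN(Cc1ccc(OCCCN)cc1)c1nc2ccc(Oc3ccc(F)cc3)cc2s1` — in an assay on SH-SY5Y cells for inhibition of Voltage-dependent N-type calcium channel subunit alpha-1B (Homo sapiens), read by FLIPR and calcium flux, with stated times of 600 s and 300 s, in the presence of a further agent that is not named here (a higher number here means a weaker inhibitor, a lower number a stronger inhibitor), compound 1 gives 98000 nM
compound 2 `N=C(N)NCCCOc1ccc(CNc2nc3ccc(Oc4ccc(F)cc4)cc3s2)cc1` — in this assay compound 2 gives 244000 nM

Compound 2 holds the higher of the two numbers in this assay; compound 1 holds the lower, and the gap between them lies beyond the usual scatter. Compound 3 `NCCCOc1ccc(CNc2nc3ccc(Oc4ccc(F)cc4)cc3s2)cc1` is the next member. It differs from compound 2 in one place: a hydrogen atom in place of a group of 3 heavy atoms (1 carbon, 2 nitrogen; no ring), on an amine nitrogen. With that group gone, the side chain of compound 3 ends in the same primary amine as the side chain of compound 1, while the amine on the shared core keeps its hydrogen instead of the methyl found in compound 1. The comparison rests on compound 1, because compound 1 gives 98000 nM in this assay. Compound 3 is therefore expected to move toward that number, a step down past the scatter, estimated as a 2.2-fold lower number from compound 2 to compound 3 (0.35 log units; beyond the scatter). Compound 3 is estimated at 110000 nM, with a range of 50000 nM to 250000 nM.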

Compound 3, half-maximal inhibitory concentration: 106000 nM
Beside the measured number, compound 3's estimate is 1.0-fold (0.02 log units) above it; the measured number falls inside the stated range.
By their numbers in this assay, from the lowest: compounds 1 and 3 (each within the scatter of the next); then compound 2.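

Among these compounds, on the amine nitrogen whose other neighbour is a saturated chain carbon, hydrogen in place of the group of 3 heavy atoms gives a 2.3-fold lower number from compound 2 to compound 3 (0.36 log units; beyond the scatter) in this assay and is the first single change here to move the number beyond the scatter, though only modestly. Hydrogen in place of methyl on a nitrogen on an aromatic ring gives a 1.1-fold higher number from compound 1 to compound 3 (0.03 log units; within the scatter) and leaves the two compounds within the scatter of each other, so with the primary amine in the side chain, this methyl shows no measurable effect. No supporting evidence bears on what lies behind either step.

Going by these compounds, how a methyl or an acetyl group on the side-chain amine nitrogen would compare remains open. So does the effect of a longer chain carrying the same primary amine.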